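Replacing the oxygen-containing ring on the sulfonyl-bound carbon

The source may hold more compounds than are shown below. What is called first, only, known or untested is meant among the compounds shown, and "the series" means these compounds.

Measured compounds:
compound 1, `O=S(=O)(CC1=NCCO1)c1c(-c2ccc(Cl)cc2)nn(-c2ccccc2)c1-c1ccc(Cl)cc1`: "not active" (no number reported)
compound 2, `COc1ccc(-c2nn(-c3ccccc3)c(-c3ccc(C)cc3)c2S(=O)(=O)CC2=NCCO2)cc1`: 66.6%

Of the compounds shown here, two of the shared core have been tested in a functional assay, read by Griess assay, with a stated time of 150 min, tested at 75 ug/mL; a higher number here means a stronger effect of the compound at the concentration tested, a lower number a weaker effect. Compound 1 (`O=S(=O)(CC1=NCCO1)c1c(-c2ccc(Cl)cc2)nn(-c2ccccc2)c1-c1ccc(Cl)cc1`) is reported as "not active" (no number reported), so no single number is available for it. Compound 2 (`COc1ccc(-c2nn(-c3ccccc3)c(-c3ccc(C)cc3)c2S(=O)(=O)CC2=NCCO2)cc1`) gives 66.6% in this assay. Among the compounds with values here, compound 2 differs from compound 1 in more than one place, so no single step can be drawn between the two, and their values show only that one of them produces a read-out while the other does not.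

Compound 3 (`O=S(=O)(CC1=NCCS1)c1c(-c2ccc(Cl)cc2)nn(-c2ccccc2)c1-c1ccc(Cl)cc1`) has not been measured. It differs from compound 1 in one place: a group of 5 heavy atoms (3 carbon, 1 nitrogen, 1 sulfur; one five-membered non-aromatic ring with 2 hetero atoms) in place of a group of 5 heavy atoms (3 carbon, 1 nitrogen, 1 oxygen; one five-membered non-aromatic ring with 2 hetero atoms), on a saturated chain carbon bound to a sulfonyl sulfur. The replaced group and the entering group each carry one five-membered non-aromatic ring with 2 hetero atoms and the same count of hydrogen-bond acceptors; only an oxygen gives way to a sulfur. Within the data shown here, nothing among the measured compounds tells how this change alters the read-out in this assay, so the expectation rests on compound 1 alone.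

Compound 3 is therefore expected to remain weak in this assay, with an estimated activity of 12%, in a range from 0% to 40%.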

Compound 3, a percentage reported as activity, at one concentration (the size of the read-out at that concentration, not a potency): "not active" (no number reported)
Nothing numeric was reported for compound 3; there is nothing to compare the estimate with.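

In this assay compound 1 gives "not active" (no number reported) and compound 3 gives "not active" (no number reported) so the two offer no numbers to compare and no new step can be read. No measured property bears on this result. The compounds shown leave open whether an oxygen giving way to a sulfur alters the read-out in a compound that produces a measurable effect.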